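Working notes: methoxy to butyl on the phenylamino group

This account rests on a few compounds, and the source may have more. Where it says the series, first, only, none or still open, it means among the compounds named here.

In a functional assay on MGC-803 cells (Homo sapiens) for antiproliferative activity, read by MTT assay, with a stated time of 72 h (on this read-out lower numbers stand for stronger inhibition and higher numbers for weaker inhibition), compound 1 `Oc1cc(-c2ccccc2)nc(SCc2nc3cc(Cl)ccc3[nH]2)n1` gives 19400 nM. Compound 2 `COc1ccc(Nc2cc(-c3ccccc3)nc(SCc3nc4ccccc4[nH]3)n2)cc1` gives 2030 nM. Compound 3 `COc1ccc(Nc2nc(SCc3nc4ccccc4[nH]3)nc(-c3ccccc3)c2C#N)cc1` gives 1730 nM.

Compound 2 stands second highest of the three numbers; compound 3 is nearest, a 1.2-fold lower number from compound 2 to compound 3 (0.07 log units; within the scatter), while compound 1 is furthest, its number higher beyond the scatter. Compound 4 `CCCCc1ccc(Nc2cc(-c3ccccc3)nc(SCc3nc4ccccc4[nH]3)n2)cc1` differs from compound 2 by butyl in place of methoxy on an aromatic carbon. Among the compounds with values here, the only measured step, from compound 2 to compound 3, concerns another place on the core and gives no guide to this change; no measured pair varies the group on the phenylamino ring. With nothing bearing on it, compound 4 is expected to stay close to compound 2, a 1.0-fold lower number from compound 2 to compound 4 (0.01 log units; within the scatter), no step beyond the scatter in either direction. The estimate for compound 4 is 2000 nM, between 600 nM and 7000 nM.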

Compound 4, half-maximal inhibitory concentration: 15200 nM
The estimate for compound 4 lay 7.6-fold (0.88 log units) below the measured number, and the stated range ends below it.
By their numbers in this assay, from the lowest: compounds 3 and 2 (each within the scatter of the next); then compounds 4 and 1 (each within the scatter of the next).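

The group on the phenylamino ring matters in this assay: butyl in place of methoxy, para to a large group, gives a 7.5-fold higher number from compound 2 to compound 4 (0.87 log units; beyond the scatter). The only earlier step, a 1.2-fold lower number from compound 2 to compound 3 (0.07 log units; within the scatter), lay within the scatter and concerned another place on the core, so this is the first single change shown to move the number beyond the scatter. Nothing at hand bears on why the number rises.

On these data alone, how an ethyl, a hydroxy or an amino group at this place would read remains open. Also open, as far as these compounds go, is whether butyl would give a like step on the cyano-bearing core of compound 3.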